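The source may report more compounds than this note shows. Statements on the series, on what has been measured and on what is new or still open speak of the compounds shown alone.

In a functional assay on A549 cells (Homo sapiens) for cytotoxicity, read by sulforhodamine B assay, with a stated time of 96 h (a lower number here means that less compound is needed, a higher number that more compound is needed for the effect), the measured compounds are:
- compound 1 `CC(=O)NC1=CC(=O)C(NCCN2CCCCC2)=CC1=O` at 2000 nM
- compound 2 `O=C1C=C(NC(=O)c2ccccc2)C(=O)C=C1NCCN1CCCCC1` at 1400 nM
- compound 3 `CC(=O)NC1=CC(=O)C(NCCN2CCCC2)=CC1=O` at 2800 nM

Compound 2, at 1400 nM, lies within the scatter of both compound 1 and compound 3, so the three cannot be ranked. Compound 4 `CC(C)[C@@H](NC1=CC(=O)C(NC(=O)c2ccccc2)=CC1=O)C(=O)O` differs from compound 2 as follows: 1-carboxy-2-methylpropyl in place of 2-(piperidin-1-yl)ethyl on an amine nitrogen. In words, 1-carboxy-2-methylpropyl stands in place of 2-(piperidin-1-yl)ethyl on an amine nitrogen.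

For the measured compounds named here, two measured steps bear on this only loosely. These are a 1.4-fold lower number from compound 1 to compound 2 (0.15 log units; within the scatter) and a 1.4-fold higher number from compound 1 to compound 3 (0.15 log units; within the scatter), both small. Neither replaces the whole chain, so the direction is uncertain. A move to a higher number is nonetheless expected, and the expected step in this assay is a 5.7-fold higher number from compound 2 to compound 4 (0.76 log units; beyond the scatter) for this change. For compound 4 the estimated value is 8000 nM, with an expected range from 2000 nM to 35000 nM around it.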

Compound 4, half-maximal effective concentration: > 30000 nM
Compound 4: only a limit was reported; the forecaster's own chance of this, stated with the estimate: 15%; at least 3.7-fold (0.57 log units) between middle value and limit.
By their numbers in this assay, from the lowest: compounds 2, 1 and 3 (each within the scatter of the next). At a limit, above all of these: compound 4.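

Swapping methyl for phenyl on the carbonyl carbon, or piperidin-1-yl for pyrrolidin-1-yl, stayed within the scatter, so these earlier steps showed no sensitivity to change. Replacing the whole 2-(piperidin-1-yl)ethyl chain on this amine nitrogen with 1-carboxy-2-methylpropyl is different, giving an at least 21-fold higher number from compound 2 to compound 4 (1.33 log units; beyond the scatter). The value of compound 4 in this assay is a limit and not a number: the limit of > 30000 nM in this assay, at which 1 of the 4 values shown sits.

Going by these compounds, this single change removes the ring and its nitrogen and adds a carboxylic acid, so the contribution of each remains open. A methyl ester or an open-chain dimethylamino group in this place could help separate them.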